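A few compounds are considered here, and "the series" means these few. Any claim that something is new, unique, unknown or untested is made for them only; others in the source may bear on it.

- Compound 1 `Cn1c(=O)c(S(=O)(=O)c2ccc(F)cc2F)cc2cnc(Nc3cccc4[nH]ccc34)nc21`: 750 nM
- Compound 2 `Cn1ccc2cc(Nc3ncc4cc(S(=O)(=O)c5ccc(F)cc5F)c(=O)n(C)c4n3)ccc21`: 750 nM

In a functional assay on DU-145 cells (Homo sapiens) for inhibition, read by trypan blue exclusion, with a stated time of 72 h (on this read-out higher numbers stand for weaker inhibition and lower numbers for stronger inhibition), compound 2 gives 750 nM, level with compound 1 at 750 nM. The next structure, compound 3 `COC(=O)Cn1ccc2cc(Nc3ncc4cc(S(=O)(=O)c5ccc(F)cc5F)c(=O)n(C)c4n3)ccc21`, keeps everything in compound 2 except for one change: methoxycarbonyl in place of hydrogen on a saturated chain carbon bound to an aromatic nitrogen. Among the compounds with values here, only one measured step is available as a guide, no change at the digits printed from compound 1 to compound 2 (within the scatter). That step placed 1-methyl-1H-indol-5-yl where 1H-indol-4-yl had been, so it changed the same part of the molecule without altering the read-out. Within the data shown here, no measured compound carries methoxycarbonyl, so this evidence is thin and the range must stay wide. The expected step is a 1.1-fold higher number from compound 2 to compound 3 (0.03 log units; within the scatter), with no shift beyond the scatter anticipated in either direction. For compound 3 the estimate is 800 nM, with an expected range of 250 nM to 2500 nM.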

Compound 3, half-maximal inhibitory concentration: 5000 nM
For compound 3 the middle estimate is 6.3-fold (0.80 log units) below the measured one; the whole stated range lies below it.
By their numbers in this assay, from the lowest: compounds 1 and 2 (each within the scatter of the next); then compound 3.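

In this assay the change from methyl to (methoxycarbonyl)methyl on this aromatic nitrogen brings a clear loss of inhibition (a 6.7-fold higher number from compound 2 to compound 3 (0.82 log units; beyond the scatter)). This is the first step shown that lies beyond the scatter, whereas the swap of the aryl group on the shared core had left the read-out unchanged (no change at the digits printed from compound 1 to compound 2 (within the scatter)). The site therefore does respond to what is attached there, and methoxycarbonyl on the saturated chain carbon is poorly tolerated in these cells, though no measurement shown here accounts for the loss.

The compounds shown leave open whether the loss follows from methoxycarbonyl itself or from any group of that size. A carboxylic acid, an amine or a plain ethyl or longer alkyl chain at the same place could separate these two readings.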